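The source may report more compounds than this note shows. Statements on the series, on what has been measured and on what is new or still open speak of the compounds shown alone.

Compound 3 `CCc1ccc2nc(C(=O)Nc3c(F)cc(-c4cccc(F)c4)cc3F)c(C)c(C(=O)O)c2c1` gives 17.7% in a functional assay on A-375 cells (Homo sapiens) for antiproliferative activity, read by MTT assay, with a stated time of 24 h, tested at 1.23 ug/mL (a lower number here means a weaker effect, a higher number a stronger effect of the compound at the concentration tested), numerically the top of the three numbers in hand, though compound 1 `CCc1ccc2nc(C(=O)Nc3c(F)cc(-c4cccc(F)c4)cc3F)c(C)c(O)c2c1`, which gives 12.3% in this assay, sits within the scatter of it. Compound 2 `Cc1c(C(=O)Nc2ccc(-c3ccccc3)cc2)nc2ccccc2c1O` gives 4.56% in this assay, a gap beyond the scatter. Among the compounds with values here, the single one-place step in hand, a number 5.4 percentage points higher from compound 1 to compound 3 (within the scatter), concerns carboxy in place of hydroxy and not the position changed now. Compound 4 `CCOc1ccc2nc(C(=O)Nc3c(F)cc(-c4cccc(F)c4)cc3F)c(C)c(C(=O)O)c2c1` differs from compound 3 by ethoxy in place of ethyl on an aromatic carbon. Within the data shown here, no measured step bears on ethoxy in place of ethyl, so the expectation rests on compound 3 alone, with no step beyond the scatter foreseen. The estimated step is no change at the digits printed from compound 3 to compound 4 (within the scatter). Compound 4 is expected to give about 17.7% in this assay, between 8% and 28%.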

Compound 4, a percentage reported as inhibition, at one concentration (the size of the read-out at that concentration, not a potency): 26.7%
Compound 4: middle estimate off by 9 percentage points, on the low side; low and high end bracket the measured number.
By their numbers in this assay, from the lowest: compounds 2, 1, 3 and 4 (each within the scatter of the next, the first and the last beyond it).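

In this assay, ethoxy in place of ethyl on this aromatic carbon, meta to a fused ring and para to a fused ring, gives a number 9 percentage points higher from compound 3 to compound 4 (within the scatter). The position therefore takes the longer group with its added hydrogen-bond acceptor without a step beyond the scatter, on a core that carries the carboxy group. No measurement in hand accounts for the step.

Going by these compounds, whether an amine or a longer chain such as butoxy at this position would move the number beyond the scatter remains open. So does whether ethoxy gives a similar step alongside hydroxy in place of carboxy.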